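Swapping Phenoxy for Dimethylamino on a Growth Inhibitor

The compounds below may be only part of what the source reports. "The series", "measured", "known", "first", "only" and "open" are said of these compounds alone.

Three related compounds have been tested in a functional assay on DU-145 cells (Homo sapiens) for inhibition, read by trypan blue exclusion, with a stated time of 96 h; a higher number here means a weaker inhibitor of growth, a lower number a stronger inhibitor of growth. Compound 1 `COc1ccccc1/C=C(\C(=O)c1ccc(Cl)cc1)S(=O)(=O)c1ccc(C)cc1` gives 1000 nM. Compound 3 `Cc1ccc(S(=O)(=O)/C(=C/c2ccc(Oc3ccccc3)cc2)C(=O)c2ccc(Cl)cc2)cc1` gives 1000 nM, which puts it level with compound 1 within the usual scatter of such measurements. Compound 2 `Cc1ccc(S/C(=C/c2ccc(N(C)C)cc2)C(=O)c2ccc(Cl)cc2)cc1` gives > 100000 nM in this assay, and this is a limit of the assay, not a number.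

The next molecule is compound 4 `Cc1ccc(S(=O)(=O)/C(=C/c2ccc(N(C)C)cc2)C(=O)c2ccc(Cl)cc2)cc1`, made from compound 3 by putting dimethylamino in place of phenoxy on an aromatic carbon. The new group is much smaller and has no ring, but it stays on the same aromatic carbon, para to a large group. Compound 4 also shares its dimethylamino group with compound 2, though the two differ elsewhere.

Within the data shown here, no measured pair shows this exact swap, so the forecast starts from compound 3 at 1000 nM. A small shift toward weaker inhibition is expected, about the size of the scatter, and the estimated change is a 2.0-fold higher number from compound 3 to compound 4 (0.30 log units; within the scatter). The range is kept wide on the weak side, given the limit seen for compound 2. For compound 4 the estimated value is 2000 nM, with an expected range from 400 nM to 20000 nM.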

Compound 4, concentration for 50% growth inhibition: > 100000 nM
Compound 4 was reported as a limit (the forecaster's own chance of this, stated with the estimate: 10%); at least 50-fold (1.69 log units) between middle value and limit.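

On an aromatic carbon para to a large group, this swap is far from neutral in this assay: dimethylamino in place of phenoxy gives an at least 100-fold higher number from compound 3 to compound 4 (2.00 log units; beyond the scatter), so growth inhibition at this position depends strongly on which group is present. A second route to the same compound agrees, since 4-(dimethylamino)phenyl in place of 2-methoxyphenyl gives an at least 100-fold higher number from compound 1 to compound 4 (2.00 log units; beyond the scatter). Both sizes are only lower bounds, and the step from compound 2 to compound 4, (4-methylphenyl)sulfonyl in place of (4-methylphenyl)sulfanyl, cannot be read, because the two compounds sit at the same limit: the limit of > 100000 nM in this assay, at which 2 of the 4 values shown sit.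

From the compounds shown here alone, whether the drop goes with the nitrogen of dimethylamino or with the loss of the phenoxy ring stays open, and so does the true distance between compound 3 and compound 4. A plain primary amine or a morpholine ring on this same aromatic carbon would help separate those two readings, since the first keeps the nitrogen without the methyl groups and the second holds a nitrogen within a ring.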